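Ester series, plasma half-life: imidazolylmethyl to diethylcarbamoyl

A few compounds are considered here, and "the series" means these few. Any claim that something is new, unique, unknown or untested is made for them only; others in the source may bear on it.

Measured so far in an ADME assay on a cell-free system (plasma, Homo sapiens) for metabolic stability; a lower number here means that the compound disappears faster, a higher number that the compound lasts longer:
- compound 1 `Cc1nccn1CCOC(=O)[C@@H](C)c1ccc(-c2ccccc2)c(F)c1` gives 5.92 h
- compound 2 `CCCCC/C=C\C/C=C\C/C=C\CCCCC(=O)OCn1cnc2c1c(=O)n(C)c(=O)n2C` gives 0.455 h
- compound 3 `CCN(CC)Cc1cccc(C(=O)OCCOCn2cnc3c(=O)[nH]c(N)nc32)c1` gives 0.125 h

Compound 1 holds the highest number of the three. The nearest value is that of compound 2, and the gap lies beyond the usual scatter; the furthest is compound 3, also beyond the scatter. Going by the values given here, no two measured compounds differ in a single place, so no measured step can guide the next change, and the three values only show the spread the series covers in this assay.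

The next compound, compound 4 `CCN(CC)C(=O)COC(=O)[C@@H](C)c1ccc(-c2ccccc2)c(F)c1`, is compared with compound 1: diethylcarbamoyl in place of (2-methyl-1H-imidazol-1-yl)methyl on a saturated chain carbon bound to an oxygen next to a carbonyl group. The shared core of compound 1 is kept unchanged, and the replaced group and the incoming group have the same heavy-atom count.

Nothing measured here speaks to this change directly. Given only that compound 1 gives 5.92 h in this assay and that the other two members fall well below it, the expectation for the step from compound 1 to compound 4 is a drop of moderate size, a 3.0-fold lower number from compound 1 to compound 4 (0.47 log units; beyond the scatter), with a wide band around it. For compound 4 the estimate is 2 h, expected between 0.3 h and 8 h.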

Compound 4, half-life: 0.0433 h
Beside the measured number, compound 4's estimate is 46-fold (1.66 log units) above it; measured number outside the range, below it.
By their numbers in this assay, from the lowest: compound 4; then compound 3; then compound 2; then compound 1.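

In this assay, going by these compounds alone, diethylcarbamoyl in place of (2-methyl-1H-imidazol-1-yl)methyl on a saturated chain carbon bound to an oxygen next to a carbonyl group gives a 140-fold lower number from compound 1 to compound 4 (2.14 log units; beyond the scatter) and provides the first single-place comparison. The shared core is unchanged and the two groups have the same heavy-atom count, so this position can strongly change the read-out even when the size of the group, counted in heavy atoms, stays the same. The change also removes the five-membered aromatic ring and brings in a double bond outside aromatic rings, but nothing available explains the size of this step.

One step cannot show whether the drop follows the loss of the ring, the arrival of the carbonyl in diethylcarbamoyl, or the two together, and a diethylaminomethyl group or a pyrrolidine-1-carbonyl group at this place would help to separate those readings. On these data alone, it also remains open whether the same replacement would give a step of similar size on an ester with a different core, such as a simple phenylacetic ester.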